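A few compounds are considered here, and "the series" means these few. Any claim that something is new, unique, unknown or untested is made for them only; others in the source may bear on it.

Measured so far:
compound 1, `Cn1c(-c2ccccc2)nnc1[S+](C)[O-]`: > 100 mg/kg
compound 2, `Cn1c(-c2ccccc2)nnc1S(C)(=O)=O`: 55 mg/kg
compound 3, `Cn1c(-c2cccc3ccccc23)nnc1[S+](C)[O-]`: > 200 mg/kg

In a functional assay on the whole organism for antagonist activity, with Mus musculus as the target (on this read-out lower numbers stand for an effect already at smaller amounts and higher numbers for an effect only at larger amounts of compound), compound 1 gives only a limit, > 100 mg/kg, not a number. Compound 2 gives 55 mg/kg in this assay. The step of an at least 1.8-fold lower number from compound 1 to compound 2 (0.25 log units; that floor lies within the scatter) goes with the change (a group of 4 heavy atoms (1 carbon, 2 oxygen, 1 sulfur; no ring) in place of a group of 3 heavy atoms (1 carbon, 1 oxygen, 1 sulfur; no ring), on an aromatic carbon). Its size is known only as a floor because compound 1 sits at the limit of > 100 mg/kg in this assay, at which 1 of the 3 values shown sits. Compound 3 likewise gives only a limit in this assay, > 200 mg/kg. The difference between the core of compound 1 and the core of compound 3 is not broken down here. Compound 4, `Cn1c(-c2cccc3ccccc23)nnc1S(C)(=O)=O`, has not yet been measured in this assay. It differs from compound 3 by a group of 4 heavy atoms (1 carbon, 2 oxygen, 1 sulfur; no ring) in place of a group of 3 heavy atoms (1 carbon, 1 oxygen, 1 sulfur; no ring), on an aromatic carbon, the same kind of change as that from compound 1 to compound 2. For the measured compounds named here, the step from compound 3 to compound 4 is expected to be of similar size to the earlier one, which rests on the step of an at least 1.8-fold lower number from compound 1 to compound 2 (0.25 log units; that floor lies within the scatter) being the only measured instance of this change. The expected step is an at least 1.8-fold lower number from compound 3 to compound 4 (0.25 log units; that floor lies within the scatter). Compound 4 is therefore expected to give about 110 mg/kg, somewhere from 40 mg/kg to 300 mg/kg.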

Compound 4, dose for half-maximal effect: > 200 mg/kg
Compound 4: no number, only a limit (the forecaster's own chance of this, stated with the estimate: 50%); middle value at least 1.8-fold (0.25 log units) away from the limit.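

In this assay compound 4 gives only a limit, > 200 mg/kg, not a number. Compound 3 is also a limit, so no step can be read between compound 3 and compound 4: the limit of > 200 mg/kg in this assay, at which 2 of the 4 values shown sit.

The compounds shown leave open whether methylsulfonyl changes the read-out on the core of compound 3 as it may on the core of compound 1.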